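The source may hold more compounds than are shown below. What is called first, only, known or untested is meant among the compounds shown, and "the series" means these compounds.

Measured compounds in the series:

compound 1, `CC(C)c1n[nH]c2c(NCc3ccc(-c4ccccn4)cc3)nc(SCCC(N)=O)nc12` — 120 nM
compound 2, `CC(C)c1n[nH]c2c(NCc3ccc(-c4ccccn4)cc3)nc(SCC3CNC(=O)O3)nc12` — 80 nM
compound 3, `CC(C)c1n[nH]c2c(NCc3ccc(-c4ccccn4)cc3)nc(SCCCN(C)C)nc12` — 105 nM

Read-out throughout is a functional assay on HT cells (Homo sapiens) for antiproliferative activity, read by fluorescence, with a stated time of 72 h; a lower number here means a stronger inhibitor of growth, a higher number a weaker inhibitor of growth. Among the three, compound 1 carries the highest number, but nothing separates it from the others with confidence: the step of a 1.1-fold lower number from compound 1 to compound 3 (0.06 log units; within the scatter) and the step of a 1.5-fold lower number from compound 1 to compound 2 (0.18 log units; within the scatter) both stay inside the scatter, as does a 1.3-fold higher number from compound 2 to compound 3 (0.12 log units; within the scatter). The three numbers are, for practical purposes, one number.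

Compound 4, `CC(C)c1n[nH]c2c(NCc3ccc(-c4ccccn4)cc3)nc(SC[C@H](O)CN)nc12`, is the next member. Against compound 1 the change is 2-amino-1-hydroxyethyl in place of carbamoylmethyl on a saturated chain carbon bound to a sulfur. The two measured steps that bear on it are those in which the same position was varied: replacing carbamoylmethyl by 2-oxo-1,3-oxazolidin-5-yl (a 1.5-fold lower number from compound 1 to compound 2 (0.18 log units; within the scatter)) and replacing carbamoyl by (dimethylamino)methyl two bonds along the chain (a 1.1-fold lower number from compound 1 to compound 3 (0.06 log units; within the scatter)). Each of these swaps altered the group on the chain bound to sulfur without moving the number beyond the scatter. The change to 2-amino-1-hydroxyethyl is of the same kind, so no step beyond the scatter is expected in this assay, in either direction.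

Estimate for compound 4 in this assay: 100 nM, with a range of 50 nM to 200 nM, which corresponds to an expected step of a 1.2-fold lower number from compound 1 to compound 4 (0.08 log units; within the scatter).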

Compound 4, concentration for 50% growth inhibition: 63 nM
Beside the measured number, compound 4's estimate is 1.6-fold (0.20 log units) above it; the measured number falls inside the stated range.
By their numbers in this assay, from the lowest: compounds 4, 2, 3 and 1 (each within the scatter of the next).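

In this assay the move to 2-amino-1-hydroxyethyl gives a 1.9-fold lower number from compound 1 to compound 4 (0.28 log units; within the scatter) and a 1.7-fold lower number from compound 3 to compound 4 (0.22 log units; within the scatter) and a 1.3-fold lower number from compound 2 to compound 4 (0.10 log units; within the scatter) and all three steps stay within the scatter. This position on a saturated chain carbon bound to a sulfur therefore also accepts a group with 2 hydrogen-bond donors and 2 hydrogen-bond acceptors, against 1 of each in carbamoylmethyl, with the same 4 heavy atoms, no double bond outside aromatic rings and 1 defined stereocentre, so the flat picture from compounds 1, 2 and 3 now extends to compound 4. No measurement shown offers an explanation for this flatness.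

Going by these compounds, all four groups on this chain carry nitrogen and a neutral or charged character cannot be separated from them here, so it remains open whether a plain butyl chain or a carboxylic acid at the same place would leave the scatter. The mirror-image form of 2-amino-1-hydroxyethyl also remains open, so the compounds shown say nothing on whether the configuration of the stereocentre in compound 4 matters.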